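Amine variation on the aryl ether chain: notes toward compound 3

The source may report more compounds than this note shows. Statements on the series, on what has been measured and on what is new or still open speak of the compounds shown alone.

Measured so far in a functional assay on MCF7 cells (Homo sapiens) for antiproliferative activity; on this read-out lower numbers stand for stronger inhibition and higher numbers for weaker inhibition:
compound 1, `CC(C)=CCc1cc(C(=O)Nc2cc3ccc(OCC4CCCN(C)C4)c(C)c3oc2=O)ccc1O`, gives 2640 nM
compound 2, `CCN(C)CCCOc1ccc2cc(NC(=O)c3ccc(O)c(CC=C(C)C)c3)c(=O)oc2c1C`, gives 2190 nM

Compound 2 holds the lowest of the two numbers, but the step of a 1.2-fold lower number from compound 1 to compound 2 (0.08 log units; within the scatter) does not separate it from compound 1. Compound 3, `CC(C)=CCc1cc(C(=O)Nc2cc3ccc(OCCCN[C@H](C)c4ccccc4)c(C)c3oc2=O)ccc1O`, is not yet measured. Its change from compound 2 is (1-phenylethyl)amino in place of ethyl(methyl)amino on a saturated chain carbon, three bonds along the chain from an oxygen on an aromatic ring.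

For the measured compounds named here, only one measured step touches the same region: exchanging the amine end of the chain gave a 1.2-fold lower number from compound 1 to compound 2 (0.08 log units; within the scatter), which shows no effect beyond the scatter. That step swapped one saturated amine for another; the present change is of a different kind, replacing ethyl(methyl)amino with (1-phenylethyl)amino and bringing in one six-membered aromatic ring and a hydrogen-bond donor. Going by the values given here, no compound in hand carries such a group, so the precedent is thin. Among the compounds with values here, the expectation is a step of a 1.5-fold lower number from compound 2 to compound 3 (0.16 log units; within the scatter), in the direction of a somewhat lower number, though the single relevant step within the scatter argues for caution. Compound 3 is therefore estimated at 1500 nM, with a range from 500 nM to 5000 nM.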

Compound 3, half-maximal inhibitory concentration: 1450 nM
Estimate against measurement, compound 3: 1.0-fold (0.01 log units) above, within the range that was stated.
By their numbers in this assay, from the lowest: compounds 3, 2 and 1 (each within the scatter of the next).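

In this assay, exchanging ethyl(methyl)amino for (1-phenylethyl)amino on the saturated chain carbon gives a 1.5-fold lower number from compound 2 to compound 3 (0.18 log units; within the scatter), so an amine end bearing a six-membered aromatic ring, a hydrogen-bond donor and a defined stereocentre leaves the number within the scatter of the smaller open-chain amine. The comparison with the cyclic amine end points the same way: 2-((1-phenylethyl)amino)ethyl in place of 1-methylpiperidin-3-yl gives a 1.8-fold lower number from compound 1 to compound 3 (0.26 log units; within the scatter), which means that compounds 1, 2 and 3 are not separated by any of their steps despite the clear difference in the groups at this end of the chain. No supporting measurement bears on this result, and no reason can be attached to it.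

The aromatic ring, the amine hydrogen and the stereocentre enter together in compound 3, so their separate contributions remain unresolved, and a benzylamino or cyclohexylamino end, or the opposite configuration of (1-phenylethyl)amino, would be needed to pull them apart. Also open, going by these compounds, is whether a longer chain, or a carboxylic acid in place of the amine, would move the number beyond the scatter.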